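Pyridin-4-yl in place of 4-(trifluoromethyl)phenyl

This account rests on a few compounds, and the source may have more. Where it says the series, first, only, none or still open, it means among the compounds named here.

In a functional assay on HepG2 cells (Homo sapiens) for antiproliferative activity, read by MTT assay, with a stated time of 48 h (on this read-out lower numbers stand for stronger inhibition and higher numbers for weaker inhibition), compound 3 (`COc1ccc(CN2C(=O)C(=O)c3cc(-c4ccc(C(F)(F)F)cc4)ccc32)cc1`) gives 820 nM, the lowest of the two numbers available in the series. The nearest neighbour of compound 3 is compound 2 (`COc1ccc(CN2C(=O)C(=O)c3cc(-c4ccc(F)cc4)ccc32)cc1`) at 3150 nM. Compound 1 (`COc1ccc(CN2C(=O)C(=O)c3cc(-c4ccc(OC)c(OC)c4)ccc32)cc1`) gives > 10000 nM, which is a limit of the assay and not a number.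

The next compound is compound 4 (`COc1ccc(CN2C(=O)C(=O)c3cc(-c4ccncc4)ccc32)cc1`), with pyridin-4-yl in place of 4-(trifluoromethyl)phenyl on an aromatic carbon of the shared core: pyridin-4-yl in place of 4-(trifluoromethyl)phenyl on an aromatic carbon. All three measured steps change the group at this same place. The step with trifluoromethyl in place of fluoro is a 3.8-fold lower number from compound 2 to compound 3 (0.58 log units; beyond the scatter), which is modest. The steps away from 3,4-dimethoxyphenyl are an at least 3.1-fold lower number from compound 1 to compound 2 (0.50 log units; beyond the scatter), at least modest, and an at least 12-fold lower number from compound 1 to compound 3 (1.08 log units; beyond the scatter), large. Within the data shown here, no measured compound carries an aromatic ring with a hetero atom, so none of these steps measures the new ring directly. The closest guide is the step to compound 3 from compound 2, since compound 4 gives up the trifluoromethyl group that accompanied a 3.8-fold lower number from compound 2 to compound 3 (0.58 log units; beyond the scatter). A modest move toward a higher number in this assay is therefore expected, and the expected step is a 3.0-fold higher number from compound 3 to compound 4 (0.48 log units; beyond the scatter). The estimate for compound 4 is 2500 nM, with an expected range from 800 nM to 8000 nM.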

Compound 4, half-maximal inhibitory concentration: > 10000 nM
Compound 4 was reported as a limit (the forecaster's own chance of this, stated with the estimate: 15%); at least 4.0-fold (0.60 log units) between middle value and limit.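

Pyridin-4-yl, the only ring at this place with a hetero atom, gives an at least 12-fold higher number from compound 3 to compound 4 (1.08 log units; beyond the scatter) and an at least 3.1-fold higher number from compound 2 to compound 4 (0.50 log units; beyond the scatter), so the loss is not confined to the trifluoromethyl compound: it also holds against compound 2, which carries fluoro instead. The value of compound 4 is a limit of the assay and not a number, so both steps give only the smallest size the change can have. Among the compounds shown, measurable inhibition is confined to compound 2 and compound 3, but a carbon-only ring alone does not secure it, as compound 1 goes against that reading, and the step between compound 1 and compound 4 cannot be read since both are limits: the limit of > 10000 nM in this assay, at which 2 of the 4 values shown sit.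

The compounds shown leave open whether the loss belongs to the ring nitrogen itself or to the missing substituent on the ring, a question that a plain phenyl group would address. Going by these compounds, how pyridin-3-yl, or a 4-aminophenyl or 4-carboxyphenyl group, would stand at this place also remains open.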